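A Second Methyl on the Core of Compound 3

The source may report more compounds than this note shows. Statements on the series, on what has been measured and on what is new or still open speak of the compounds shown alone.

Compound 1 `Fc1ccc(-c2nn(-c3ccccc3)cc2-c2nc3ccccc3[nH]2)cc1` gives 3200 nM in a functional assay on MCF7 cells (Homo sapiens) for antiproliferative activity, read by MTT assay, with a stated time of 48 h; a higher number here means a weaker inhibitor, a lower number a stronger inhibitor. Compound 2 `Cc1ccc2[nH]c(-c3cn(-c4ccccc4)nc3-c3ccc(F)cc3)nc2c1` gives 1120 nM. Compound 3 `COc1ccc(-c2nn(-c3ccccc3)cc2-c2nc3cc(C)ccc3[nH]2)cc1` gives 6610 nM.

Compound 2 differs from compound 1 by one change (methyl in place of hydrogen on an aromatic carbon), and this gave a 2.9-fold lower number from compound 1 to compound 2 (0.46 log units; beyond the scatter). Compound 3 differs from compound 2 by a single change, and the step was a 5.9-fold higher number from compound 2 to compound 3 (0.77 log units; beyond the scatter). How the cores of compound 1 and compound 3 differ is not broken down here.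

Compound 4 `COc1ccc(-c2nn(-c3ccccc3)cc2-c2nc3cc(C)c(C)cc3[nH]2)cc1` is yet to be measured. It differs from compound 3 by methyl in place of hydrogen on an aromatic carbon. This is the same kind of change as that from compound 1 to compound 2, though here the place is also ortho to a methyl group. The estimate for compound 4 is a 2.4-fold lower number from compound 3 to compound 4 (0.37 log units; beyond the scatter), resting on the step of a 2.9-fold lower number from compound 1 to compound 2 (0.46 log units; beyond the scatter) seen for compound 2. Compound 4 is therefore expected to give about 2800 nM, between 1000 nM and 7000 nM.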

Compound 4, half-maximal inhibitory concentration: 12800 nM
The estimate for compound 4 lay 4.6-fold (0.66 log units) below the measured number; measured number outside the range, above it.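

In this assay, methyl in place of hydrogen on an aromatic carbon did not give the same result on the second core, where the step was a 1.9-fold higher number from compound 3 to compound 4 (0.29 log units; within the scatter). Set beside the earlier step, the two results differ: the same change on two cores in this assay, a 2.9-fold lower number (0.46 log units; beyond the scatter) from compound 1 to compound 2 and a 1.9-fold higher number (0.29 log units; within the scatter) from compound 3 to compound 4, 5.5-fold (0.74 log units) apart, beyond the scatter of two such steps
So the step seen on the core of compound 1 cannot simply be carried to the core of compound 3, but one pair on each core does not show whether the methyl's place, ortho to a methyl group, or the methoxy elsewhere on the core accounts for the difference.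

The compounds shown leave open whether this second methyl would behave alike on the core of compound 2, which carries fluoro instead of methoxy. They also leave open how an amine or a longer chain would fare at the same place.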